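Benzyl thioether series: methyl to chloro on the benzyl ring

The source may report more compounds than this note shows. Statements on the series, on what has been measured and on what is new or still open speak of the compounds shown alone.

Compound 3 `Cc1cc(-c2ccccc2)n(/C(N)=N/S(=O)(=O)c2cc(C)c(Cl)cc2SCc2ccccc2C)n1` carries a (2-methylbenzyl)sulfanyl group on the shared core. Among the measured compounds shown here, in a functional assay on HeLa cells (Homo sapiens) for cytotoxicity, read by MTT assay, with a stated time of 72 h (a higher number here means a weaker inhibitor, a lower number a stronger inhibitor), compound 3 gives 160000 nM, the highest of the three numbers so far. Compound 2 `Cc1cccc(CSc2cc(Cl)c(C)cc2S(=O)(=O)/N=C(\N)n2nc(C)cc2-c2ccccc2)c1` gives 155000 nM in this assay, and the step of a 1.0-fold higher number from compound 2 to compound 3 (0.01 log units; within the scatter) lies within the scatter, so these two compounds stand level. Compound 1 `Cc1cc(-c2ccccc2)n(/C(N)=N/S(=O)(=O)c2cc(C)c(Cl)cc2SCc2cccc3ccccc23)n1` gives 3000 nM in this assay; the steps of a 52-fold higher number from compound 1 to compound 2 (1.71 log units; beyond the scatter) and a 53-fold higher number from compound 1 to compound 3 (1.73 log units; beyond the scatter) are large, and compound 3 therefore sits far from compound 1.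

Compound 4 `Cc1cc(-c2ccccc2)n(/C(N)=N/S(=O)(=O)c2cc(C)c(Cl)cc2SCc2ccccc2Cl)n1` differs from compound 3 by chloro in place of methyl on an aromatic carbon. For the measured compounds named here, no measured step covers this exact exchange. The two large steps concern replacement of naphthalen-1-yl by a methylphenyl ring and say nothing about a single substituent swap within a six-membered ring. Going by the values given here, the only step that keeps a methylphenyl ring, a 1.0-fold higher number from compound 2 to compound 3 (0.01 log units; within the scatter), relocated the methyl group and stayed within the scatter. On that basis the expected step for compound 4 is a 1.1-fold lower number from compound 3 to compound 4 (0.03 log units; within the scatter), that is, none beyond the scatter in this assay. Compound 4 is expected to give 150000 nM in this assay, with an estimated range from 50000 nM to 450000 nM.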

Compound 4, half-maximal inhibitory concentration: 270000 nM
Compound 4: middle estimate off by 1.8-fold (0.26 log units), on the low side; measured number inside the range.
By their numbers in this assay, from the lowest: compound 1; then compounds 2, 3 and 4 (each within the scatter of the next).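

In this assay, among the compounds shown here, the exchange of chloro for methyl on an aromatic carbon, ortho to a large group, gives the first reading of a change of substituent type at this ring: the step of a 1.7-fold higher number from compound 3 to compound 4 (0.23 log units; within the scatter) lies within the scatter, as does the step of a 1.7-fold higher number from compound 2 to compound 4 (0.24 log units; within the scatter), so compounds 2, 3 and 4 stand level. The gap to the naphthalen-1-yl compound holds for a third substituted phenyl ring, with the step of a 90-fold higher number from compound 1 to compound 4 (1.95 log units; beyond the scatter) large, and among the four compounds none goes against this split between the naphthalen-1-yl ring and the substituted phenyl rings. Nothing available bears on why the chloro and methyl compounds read alike or why compound 1 stands apart.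

As far as these compounds go, how an amine or a carboxylic acid at this same ring carbon would read stays open, as does whether any group on this ring can bring the number close to that of compound 1, which gives 3000 nM. From the compounds shown here alone, it is also open whether that lower number is particular to the naphthalen-1-yl attachment or would carry over to a naphthalen-2-yl group on the same chain carbon.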